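Sulfonyl piperidine series: cytotoxicity readings, all at limits

This account rests on a few compounds, and the source may have more. Where it says the series, first, only, none or still open, it means among the compounds named here.

Measured so far:
compound 1 `CC1CCN(C2CCN(S(=O)(=O)c3cccnc3Cl)CC2)CC1` — > 10000 nM
compound 2 `COc1cc(C)ccc1S(=O)(=O)N1CCC(N2CCC(C)CC2)CC1` — > 5000 nM
compound 3 `CC1CCCN(C2CCN(S(=O)(=O)c3ccc(OC(F)F)cc3)CC2)C1` — > 5000 nM

In an ADME assay on HCT-116 cells (Homo sapiens) for cytotoxicity, read by CellTiter-Glo, with a stated time of 72 h (on this read-out lower numbers stand for stronger inhibition and higher numbers for weaker inhibition), compound 1 gives > 10000 nM, which is a limit of the assay and not a number. Compound 2 gives > 5000 nM in this assay, also a limit. Compound 3 gives > 5000 nM in this assay, a limit as well. Among the compounds with values here, no measured pair differs in a single place, so no measured step can be drawn; what the three values show is that none of them reaches a measurable value, as seen in the limit of > 10000 nM in this assay, at which 1 of the 3 values shown sits, and (the limit of > 5000 nM in this assay, at which 2 of the 3 values shown sit).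

Compound 4 `CC1CCN(C2CCN(S(=O)(=O)c3cccc(Cl)c3)CC2)CC1` has not yet been measured in this assay. It differs from compound 1 by 3-chlorophenyl in place of 2-chloropyridin-3-yl on a sulfonyl sulfur. Since compound 1 sits at a limit and every other reading in the series is likewise a limit, no step beyond the scatter is expected for this change. Expected is a step that the limit leaves unreadable from compound 1 to compound 4, none beyond the scatter. For compound 4 the estimate in this assay is 20000 nM, with a range from 5000 nM to 100000 nM, most likely reported again only as a limit.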

Compound 4, half-maximal inhibitory concentration: > 5000 nM
Compound 4 gave a limit, no number; the forecaster's own chance of this, stated with the estimate: 85%; the middle value lies beyond the limit too.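

Compound 1 and compound 4 both stand at limits in this assay, not at numbers, and the step between them cannot be read. The compounds shown leave open whether 3-chlorophenyl in place of 2-chloropyridin-3-yl on a sulfonyl sulfur changes the read-out at all, and whether any of them reaches a measurable value.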